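The source may report more compounds than this note shows. Statements on the series, on what has been measured and on what is new or still open speak of the compounds shown alone.

Measured compounds in a functional assay on A-375 cells (Homo sapiens) for cytotoxicity, read by MTT assay, with a stated time of 72 h, tested at 10 uM; on this read-out lower numbers stand for less inhibition of growth and higher numbers for more inhibition of growth at the one concentration tested:
compound 1, `Cc1ccnc(/C(N)=N/NC(=S)N2CCOCC2)c1`, gives 86%
compound 2, `Cc1ccnc(/C(N)=N/NC(=S)N2CCSCC2)c1`, gives 74.5%
compound 3, `N/C(=N\NC(=S)N1CCSCC1)c1ccc(F)cn1`, gives 70.9%

Compounds 1 and 2 share one core; compound 3 carries a different one, and the difference between the two cores is not broken down here. Within the first pair the only change is morpholin-4-yl in place of thiomorpholin-4-yl on a thiocarbonyl carbon, and this change made the step of a number 11.5 percentage points higher from compound 2 to compound 1 (beyond the scatter). The values of compound 2 and compound 3 lie within the usual scatter of each other, so no order between them is claimed; compound 1 lies beyond the scatter above compound 3.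

Compound 4, `N/C(=N\NC(=S)N1CCOCC1)c1ccc(F)cn1`, is not yet measured. It differs from compound 3 by morpholin-4-yl in place of thiomorpholin-4-yl on a thiocarbonyl carbon, which is the same change as from compound 2 to compound 1, made on the other core; the place of the change is described in the same words for both pairs. The change occurs twice among these compounds, and only one of the two steps is known.

For the measured compounds named here, for compound 4 the step of a number 10.1 percentage points higher from compound 3 to compound 4 (beyond the scatter) is expected, resting on the one earlier step because that step is a number 11.5 percentage points higher from compound 2 to compound 1 (beyond the scatter) and the same change is made at the same kind of place. Whether the second core carries the change the same way cannot be checked against any other pair here, so the expected range is kept wide. Compound 4 is therefore estimated at 81%, between 70% and 92%.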

Compound 4, percent growth inhibition at one concentration: 70.3%
Compound 4: the middle estimate sits 10.7 percentage points above what was measured, and the stated range covers the measured number.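

In this assay, morpholin-4-yl in place of thiomorpholin-4-yl on a thiocarbonyl carbon gives, on the second core, a number 0.6 percentage points lower from compound 3 to compound 4 (within the scatter), so no effect of the change can be read on this core. Set beside the step on the first core, a number 11.5 percentage points higher from compound 2 to compound 1 (beyond the scatter), the two results cannot be separated: the same change on two cores in this assay, a number 11.5 percentage points higher (beyond the scatter) from compound 2 to compound 1 and a number 0.6 percentage points lower (within the scatter) from compound 3 to compound 4, 12.1 percentage points apart, within the scatter of two such steps. For the compounds shown here, the series therefore does not show that the core alters the effect of this change, nor does it show that the step seen on the first core carries over at the same size, since each core offers only one pair, and the step beyond the scatter on the first core remains no rule for the second.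

Still open, on these data alone, is how other groups on the thiocarbonyl carbon compare with this pair, for example piperidin-1-yl, a piperazine ring or an open-chain dimethylamino group. Also open, as far as these compounds go, is whether a further core, such as one bearing a chloro or methoxy substituent, would follow the first core, the second or neither, and whether a full concentration series would tell the morpholin-4-yl and thiomorpholin-4-yl compounds apart more sharply than readings at a single concentration.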